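Lengthening an ethyl chain on an inactive compound

The source may report more compounds than this note shows. Statements on the series, on what has been measured and on what is new or still open speak of the compounds shown alone.

Compound 1 `CCN1CCN(c2ccc(S(=O)(=O)Oc3ccccc3OC)cc2)C1=O`: > 100000 nM, a limit
Compound 2 `CCN1CCN(c2ccc(S(=O)(=O)Oc3ccc(OC)cc3)cc2)C1=O`: > 100000 nM, a limit

In a functional assay on MCF7 cells (Homo sapiens) for antiproliferative activity, read by sulforhodamine B assay, with a stated time of 48 h (on this read-out lower numbers stand for stronger inhibition and higher numbers for weaker inhibition), compound 1 gives > 100000 nM, which is a limit and not a number. Compound 2 shares it, so the data show (the limit of > 100000 nM in this assay, at which 2 of the 2 values shown sit). Among the compounds with values here, the one measured step is a step that the two limits leave unreadable from compound 1 to compound 2. It concerns the methoxyphenyl group, so compound 2 offers no size to carry over.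

Compound 3 `CCCN1CCN(c2ccc(S(=O)(=O)Oc3ccccc3OC)cc2)C1=O` differs from compound 1 in another place: methyl in place of hydrogen on a saturated chain carbon, two bonds along the chain from an amide-type nitrogen in a ring, which turns ethyl into propyl. Within the data shown here, no measured step touches this chain, so no change beyond the scatter can be expected in this assay, in either direction, and another limit is likely. The expected step is a number no higher from compound 1 to compound 3 (the limit leaves the size open). Compound 3 is estimated at 100000 nM, with an expected range of 30000 nM to 300000 nM.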

Compound 3, half-maximal inhibitory concentration: 13000 nM
Compound 3: middle estimate off by 7.7-fold (0.89 log units), on the high side; measured number below the stated range.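

Turning ethyl into propyl on the ring nitrogen's chain gives an at least 7.6-fold lower number from compound 1 to compound 3 (0.88 log units; beyond the scatter) in this assay. Within the data shown here, this is the first readable change: a single added methyl on a saturated chain carbon, two bonds along the chain from an amide-type nitrogen in a ring, is enough to bring a measurable number out of an inactive compound. Compound 3 is also the only compound shown that escapes the ceiling of the assay, so the step gives a minimum size and the true gap could be larger: the limit of > 100000 nM in this assay, at which 2 of the 3 values shown sit.

On these data alone, whether the trend goes on with a longer chain such as butyl or pentyl, or holds for a branched group such as isopropyl, remains open. It is also unknown whether propyl would have the same effect with the 4-methoxyphenyl group of compound 2.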